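The compounds below may be only part of what the source reports. "The series", "measured", "known", "first", "only" and "open" are said of these compounds alone.

Measured so far in a functional assay on KKU-M213 cells (Homo sapiens) for cytotoxicity, read by MTT assay; a higher number here means a weaker inhibitor, a lower number a stronger inhibitor:
- compound 1 `Cc1cc(O)c(C=O)c2c1C(=O)Oc1c(O)c3c(c(C)c1O2)C(=O)CC(C)(C)O3` gives 3 ug/mL
- compound 2 `Cc1cc(O)c(C=O)c2c1C(=O)Oc1c(cc3c(c1C)C(=O)CC(C)(C)O3)O2` gives 6.94 ug/mL

Compound 1 has the lower of these two numbers, and the gap to compound 2 lies beyond the scatter. Compound 3 `Cc1c2c(c(O)c3c1C(=O)CC(C)(C)O3)OC(=O)c1c(C)c(Cl)c(O)c(C=O)c1O2` has not yet been measured. It is compound 1 with chloro in place of hydrogen on an aromatic carbon, ortho to a hydroxy group and ortho to a methyl group (chloro in place of hydrogen on an aromatic carbon). Among the compounds with values here, no measured pair shows this change, so only a small shift toward stronger inhibition is expected, possibly none beyond the scatter. The expected step is a 1.2-fold lower number from compound 1 to compound 3 (0.08 log units; within the scatter). Compound 3 is estimated at 2.5 ug/mL, with an expected range of 1 ug/mL to 6.5 ug/mL.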

Compound 3, half-maximal inhibitory concentration: 4.98 ug/mL
Compound 3: middle estimate off by 2.0-fold (0.30 log units), on the low side; the measured number falls inside the stated range.
By their numbers in this assay, from the lowest: compounds 1, 3 and 2 (each within the scatter of the next, the first and the last beyond it).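

In this assay, chloro in place of hydrogen on the aromatic carbon ortho to a hydroxy group and ortho to a methyl group gives a 1.7-fold higher number from compound 1 to compound 3 (0.22 log units; within the scatter), the only single-place step among these compounds. This position therefore accepts chloro with no shift that stands clear of the scatter. Nothing available explains this result. Still open, from the compounds shown here alone, is whether a different group on this carbon, such as an amine, a methoxy group or a carboxylic acid, would move the number beyond the scatter. Also open, going by these compounds, is whether chloro would give a similar step on compound 2.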